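A few compounds are considered here, and "the series" means these few. Any claim that something is new, unique, unknown or untested is made for them only; others in the source may bear on it.

Measured so far:
compound 1 `Cc1ccc(S(=O)(=O)Nc2ccc(C(=O)/C=C/c3ccc([N+](=O)[O-])cc3)cc2)cc1` — 26000 nM
compound 2 `C/C(=N/n1c(N)cc(N)c(C#N)c1=O)c1ccc(NS(=O)(=O)c2ccccc2)cc1` — 25500 nM

Both numbers come from a functional assay on HepG2 cells (Homo sapiens) for cytotoxicity, read by sulforhodamine B assay, with a stated time of 48 h; a higher number here means a weaker inhibitor, a lower number a stronger inhibitor. Compound 1 gives the larger of the two figures, but the gap to compound 2 lies within the scatter, so the two are not separated. Within the data shown here, no step between measured compounds is available. Compound 3 `Cc1ccc(S(=O)(=O)Nc2ccc(C(=O)/C=C/c3ccccc3)cc2)cc1` differs from compound 1 by hydrogen in place of nitro on an aromatic carbon. With nothing in the series to rest on, the expected step of a 1.5-fold higher number from compound 1 to compound 3 (0.19 log units; within the scatter) is small, toward a weaker inhibitor, possibly none beyond the scatter. Compound 3 is therefore expected to give 40000 nM in this assay, with a range of 15000 nM to 100000 nM.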

Compound 3, half-maximal inhibitory concentration: "not active" (no number reported)
Compound 3 has no reported number here, so the estimate cannot be set against anything.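

Among these compounds, compound 3 is reported as "not active" in this assay without a number, so no step from compound 1 to compound 3 can be read. From the compounds shown here alone, how far 4-nitrophenyl to phenyl shifts the response stays open. No supporting evidence bears on this result.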